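Fluoro in place of cyano: an expected whole-organism result

The source may hold more compounds than are shown below. What is called first, only, known or untested is meant among the compounds shown, and "the series" means these compounds.

Measured so far:
Compound 1 `Nc1ncnn1/C(S)=N/Cc1ccccc1`: 40%
Compound 2 `C/N=C(\S)n1nc(-c2ccc(C#N)cc2)nc1N`: 87%

Among the compounds with values here, in a functional assay on the whole organism for inhibition, with Rattus norvegicus as the target, at a dose of 30 mg/kg (on this read-out higher numbers stand for more inhibition at the one dose given (going by the name of the read-out) and lower numbers for less inhibition), compound 2 gives 87%, the higher of the two numbers known, while compound 1 gives 40%, a gap beyond the scatter. The two share no single-point change, so only their values can be compared. Compound 3 `C/N=C(\S)n1nc(-c2ccc(F)cc2)nc1N` differs from compound 2 by fluoro in place of cyano on an aromatic carbon. Within the data shown here, no measured pair shows this change, so the size of the step in this assay is open; a moderate fall is expected, though a step within the scatter would not surprise. Compound 3 is estimated at 65%, between 35% and 90%. The expected step is a number 22 percentage points lower from compound 2 to compound 3 (beyond the scatter).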

Compound 3, a percentage reported as inhibition, in the whole organism at one dose (the size of the read-out at that dose, not a potency): 73%
Compound 3: middle estimate off by 8 percentage points, on the low side; low and high end bracket the measured number.
By their numbers in this assay, from the lowest: compound 1; then compound 3; then compound 2.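

In this assay, swapping cyano for fluoro on this aromatic carbon gives the first measured size for a single change: a number 14 percentage points lower from compound 2 to compound 3 (beyond the scatter). The group at this place therefore affects the read-out, yet the nitrile is not required for substantial inhibition, since compound 3 still gives 73%. Nothing available explains why the number falls. As far as these compounds go, how an amine, a carboxylic acid or a methoxy group at this place would compare remains open. So does whether the same swap would give a similar step at another dose.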